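A few compounds are considered here, and "the series" means these few. Any claim that something is new, unique, unknown or untested is made for them only; others in the source may bear on it.

In an assay on isolated protein for inhibition of Dihydrofolate reductase (Homo sapiens), read by spectrophotometry (a higher number here means a weaker inhibitor, a lower number a stronger inhibitor), compound 1 `CC1=Nc2c(O)nc(N)nc2OC1C` gives 377000 nM.
In this assay, compound 2 `Nc1nc(O)c2c(n1)OCC(CCc1ccccc1)=N2` gives 3000 nM.

Of the two numbers in hand, compound 2 holds the lower one; its nearest neighbour is compound 1, whose number is higher by a margin well beyond the scatter of this kind of measurement. Among the compounds with values here, no pair among the measured compounds differs in a single place, so no measured step is available to lean on.

Compound 3 `Nc1nc(O)c2c(n1)OCC(CCCc1ccccc1)=N2` has not been measured in this assay. It differs from compound 2 in one place: benzyl in place of phenyl on a saturated chain carbon, two bonds along the chain from a carbon with a double bond to nitrogen. Nothing in the measured data speaks directly to a change of this sort, so the expectation rests only on the shared core and on the number for compound 2. The step from compound 2 to compound 3 in this assay is expected to be small, no change at the digits printed from compound 2 to compound 3 (within the scatter), and quite possibly within the scatter in either direction. Compound 3 is accordingly estimated at 3000 nM, with a range from 1000 nM to 10000 nM.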

Compound 3, half-maximal inhibitory concentration: 7000 nM
The estimate for compound 3 lay 2.3-fold (0.37 log units) below the measured number; the measured number falls inside the stated range.
By their numbers in this assay, from the lowest: compound 2; then compound 3; then compound 1.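

In this assay, within the data shown here, benzyl in place of phenyl on a saturated chain carbon, two bonds along the chain from a carbon with a double bond to nitrogen, gives a 2.3-fold higher number from compound 2 to compound 3 (0.37 log units; beyond the scatter), the only single-place step in the set, and it shows that this position responds to the change, modestly but beyond the scatter, in the direction of a weaker inhibitor. The two groups have the same counts of hydrogen-bond donors and acceptors, the same six-membered aromatic ring of carbon only and no net charge. Benzyl has seven heavy atoms and phenyl has six. Nothing measured here explains why the number moves with this change.

A single step cannot show whether the number would keep rising with a longer chain carrying the same ring, or whether this step is the start of any trend at all. It also leaves open how the position would respond if an amine or a carboxylic acid stood in place of benzyl, since every group seen here is a carbon-only aromatic one.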